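A few compounds are considered here, and "the series" means these few. Any claim that something is new, unique, unknown or untested is made for them only; others in the source may bear on it.

Compound 2 `CCCCN(c1nc2c(CO)cccc2o1)[C@H](C)c1ccc(-c2ccccc2-c2nnn[nH]2)cc1` stands lowest of the two numbers in an ADME assay on the whole organism (Macaca fascicularis) for pharmacokinetics, read by LC-MS, using cassette dosing (a higher number here means that a larger share of the oral dose reaches the circulation, a lower number that a smaller share of the oral dose reaches the circulation), where compound 2 gives 0.8%. Compound 1 `CCCCN(c1nc2c(-c3nccn3C)cccc2o1)[C@H](C)c1ccc(-c2ccccc2-c2nnn[nH]2)cc1` gives 7.5% in this assay, and the step of a number 6.7 percentage points lower from compound 1 to compound 2 (within the scatter) remains within the scatter. Compound 3 `CCCCN(c1nc2c(C(=O)N(C)C)cccc2o1)[C@H](C)c1ccc(-c2ccccc2-c2nnn[nH]2)cc1` carries dimethylcarbamoyl in place of hydroxymethyl on an aromatic carbon. Within the data shown here, the single measured step at that aromatic carbon, a number 6.7 percentage points lower from compound 1 to compound 2 (within the scatter), lay within the scatter, so no step beyond the scatter is expected here. Compound 3 is accordingly estimated at 3%, with a range from 0.3% to 12%. The expected step is a number 2.2 percentage points higher from compound 2 to compound 3 (within the scatter).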

Compound 3, oral bioavailability: 6.7%
Compound 3: middle estimate off by 3.7 percentage points, on the low side; the range from low to high includes it.
By their numbers in this assay, from the lowest: compounds 2, 3 and 1 (each within the scatter of the next).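

In this assay, among these compounds, dimethylcarbamoyl on this aromatic carbon gives a number 5.9 percentage points higher from compound 2 to compound 3 (within the scatter) and a number 0.8 percentage points lower from compound 1 to compound 3 (within the scatter) as its two steps, so a third group joins the first two without a step beyond the scatter. The hydroxymethyl, 1-methyl-1H-imidazol-2-yl and dimethylcarbamoyl groups thus cannot be told apart at this position, although the last brings no hydrogen-bond donor and no ring. No evidence is available that bears on this result. Going by these compounds, whether an amine, a carboxylic acid or a longer chain on this carbon would give a step beyond the scatter remains open.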